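Nitro in Place of Chloro: an Expected Value

The source may report more compounds than this note shows. Statements on the series, on what has been measured and on what is new or still open speak of the compounds shown alone.

Compound 1 `CC(C)(C)c1cc(OC(=O)c2ccc(Cl)cc2Cl)ccc1O` gives 10200 nM in an assay on isolated protein for antagonist activity at Bile acid receptor (Homo sapiens), read by HTRF, with a stated time of 30 min; on this read-out lower numbers stand for stronger inhibition and higher numbers for weaker inhibition.
Compound 2 `CC(C)(C)c1cc(OC(=O)c2ccc(Cl)cc2)ccc1O` reaches only a limit of this assay, > 100000 nM.

Compound 1 holds the only number shown in this assay; the other value is a limit. Going by the values given here, the one measured step, an at least 9.8-fold higher number from compound 1 to compound 2 (0.99 log units; beyond the scatter), shows that taking away a chloro group weakens inhibition, and the size of that step rests on (the limit of > 100000 nM in this assay, at which 1 of the 2 values shown sits). Compound 3 `CC(C)(C)c1cc(OC(=O)c2ccc([N+](=O)[O-])cc2Cl)ccc1O` differs from compound 1 by nitro in place of chloro on an aromatic carbon. The measured step bears on this change only in part: it too removes a chloro group, but nothing shown tells what a nitro group brings in its stead. A weakening step is therefore expected for compound 3, though a smaller one than the measured step, and the estimate is 20000 nM with a range from 5000 nM to 100000 nM, meaning a 2.0-fold higher number from compound 1 to compound 3 (0.29 log units; within the scatter).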

Compound 3, half-maximal inhibitory concentration: 8800 nM
Beside the measured number, compound 3's estimate is 2.3-fold (0.36 log units) above it, within the range that was stated.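

In this assay, the position para to a large group accepts nitro in place of chloro with a 1.2-fold lower number from compound 1 to compound 3 (0.06 log units; within the scatter), so the two groups cannot be told apart at this position. The earlier weakening, an at least 9.8-fold higher number from compound 1 to compound 2 (0.99 log units; beyond the scatter), came from losing the chloro group that stands meta to this position, and compound 3 keeps that group, so the earlier step concerned a different position from the one changed here. Nothing shown accounts for why nitro and chloro read alike here.

As far as these compounds go, what hydrogen alone would give at this position, with the other chloro group kept, remains open. From the compounds shown here alone, it is also open whether an amine or a carboxylic acid would be accepted here as nitro is, and whether nitro could stand in for the other chloro group.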